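This account rests on a few compounds, and the source may have more. Where it says the series, first, only, none or still open, it means among the compounds named here.

Compound 2 `COc1ccc(OCc2ccccn2)c(CCCNC(C)=O)c1` gives 1.61 nM in an assay on CHO cells for displacement of a labelled ligand from melatonin receptor type 1B (Homo sapiens), read by scintillation counting, with a stated time of 60 min (on this read-out lower numbers stand for stronger inhibition and higher numbers for weaker inhibition), the lowest of the two numbers measured in this assay. Among the measured compounds shown here, its only measured neighbour is compound 1 `COc1ccc(OCCc2ccccc2)c(CCCNC(C)=O)c1`, which gives 13.4 nM in this assay, and the single step between them, an 8.3-fold lower number from compound 1 to compound 2 (0.92 log units; beyond the scatter), came from changing the group on a saturated chain carbon bound to an oxygen on an aromatic ring. Compound 3 `COc1cccc(COc2ccc(OC)cc2CCCNC(C)=O)c1` changes the same spot again: 3-methoxyphenyl in place of pyridin-2-yl on a saturated chain carbon bound to an oxygen on an aromatic ring. That step bears directly on the earlier one, since it removes the ring with a nitrogen and puts back a carbon-only ring, now carrying a methoxy group. As far as these compounds go, because that earlier step, an 8.3-fold lower number from compound 1 to compound 2 (0.92 log units; beyond the scatter), was beyond the scatter, a move in the opposite direction is expected, though the methoxy group is untested here and softens the call. The estimate for compound 3 in this assay is 8 nM, from 2.5 nM to 25 nM, meaning an expected step of a 5.0-fold higher number from compound 2 to compound 3 (0.70 log units; beyond the scatter).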

Compound 3, inhibition constant: 0.00069 nM
Compound 3: middle estimate off by 12000-fold (4.06 log units), on the high side; measured number below the stated range.
By their numbers in this assay, from the lowest: compound 3; then compound 2; then compound 1.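

At the saturated chain carbon bound to an oxygen on an aromatic ring, the number responds far more strongly than the first step showed. In this assay, 3-methoxyphenyl in place of pyridin-2-yl gives a 2300-fold lower number from compound 2 to compound 3 (3.37 log units; beyond the scatter), so a ring with a nitrogen is not needed for a low number at this spot. Against benzyl, the same group gives a 19000-fold lower number from compound 1 to compound 3 (4.29 log units; beyond the scatter), far larger than the earlier 8.3-fold lower number from compound 1 to compound 2 (0.92 log units; beyond the scatter), and no measurement shown gives a reason for a step of this size.

This change swaps the ring with a nitrogen for a carbon-only ring and brings in the methoxy group at once, so the compounds shown cannot tell which of the two carries the step. As far as these compounds go, how plain phenyl or 3-hydroxyphenyl would read at this spot stays open.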